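The source may hold more compounds than are shown below. What is called first, only, known or untested is meant among the compounds shown, and "the series" means these compounds.

Measured compounds in a functional assay on MDA-MB-231 cells (Homo sapiens) for inhibition, read by CCK-8 assay, with a stated time of 48 h; a higher number here means a weaker inhibitor of growth, a lower number a stronger inhibitor of growth:

Compound 1, `Cc1ccccc1Nc1nc(Nc2ccccc2)ncc1Cl`: > 100000 nM
Compound 2, `Cc1ccccc1Nc1nc(Nc2ccc(N3CCCCC3)cc2)ncc1Cl`: 19900 nM
Compound 3, `CN1CCN(c2ccc(Nc3ncc(Cl)c(NCc4ccc(F)cc4)n3)nc2)CC1`: > 100000 nM

The value for compound 1 is a limit of the assay, not a number. The value for compound 3 is likewise a limit. Compound 3 therefore sits at the limit of > 100000 nM in this assay, at which 2 of the 3 values shown sit, with no measured number of its own, so its standing among the three can only be described as at the limit.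

Compound 4, `CC(C)c1cccc(Nc2nc(Nc3ccc(N4CCN(C)CC4)cn3)ncc2Cl)c1`, differs from compound 3 by 3-isopropylphenyl in place of 4-fluorobenzyl on a nitrogen on an aromatic ring. Among the compounds with values here, the one measured step, an at least 5.0-fold lower number from compound 1 to compound 2 (0.70 log units; beyond the scatter), concerns a change on an aromatic carbon and does not touch the nitrogen where compound 4 differs from compound 3, so no measured step bears directly on this change. Within the data shown here, without such a precedent, and with compound 3 known only as a limit, the estimate rests on the observation that compound 2, the only compound with a number, also carries an amine-linked aryl group on both sides of the core. Compound 4 is expected to show a step of an at least 4.0-fold lower number from compound 3 to compound 4 (0.60 log units; beyond the scatter) in this assay. Compound 4 is thus estimated at 25000 nM, within a range from 3000 nM to 100000 nM.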

Compound 4, concentration for 50% growth inhibition: 5590 nM
Compound 4: middle estimate off by 4.5-fold (0.65 log units), on the high side, and the stated range covers the measured number.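

Putting 3-isopropylphenyl in place of 4-fluorobenzyl on a nitrogen on an aromatic ring gives, in this assay, an at least 17-fold lower number from compound 3 to compound 4 (1.25 log units; beyond the scatter). This shows that the group on this nitrogen matters for growth inhibition, which the earlier step on an aromatic carbon could not show. Compound 3 stands at a limit, so the size of this step is a bound and not an exact figure: the limit of > 100000 nM in this assay, at which 2 of the 4 values shown sit.

The compounds shown leave open whether the step comes from the isopropyl group itself or from the change from (4-fluorobenzyl)amino to (3-isopropylphenyl)amino as a whole. They also leave open how a 3-methoxyphenyl or a 3-carboxyphenyl group on this nitrogen would compare with the 3-isopropylphenyl group of compound 4.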